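Series notes: three limits and one untested analogue

The source may hold more compounds than are shown below. What is called first, only, known or untested is meant among the compounds shown, and "the series" means these compounds.

Measured compounds:
compound 1 `O=C(CSc1cccc(O)c1)Nc1ccc2nc(NC(=O)c3ccccc3)sc2c1` — > 100000 nM
compound 2 `Cn1c(CNC(=O)c2cccs2)nnc1SCC(=O)Nc1cccc(Cl)c1` — > 100000 nM
compound 3 `O=C(CSc1nnc(NC(=O)COc2ccccc2)s1)Nc1ccc(Br)cc1` — > 100000 nM

In a functional assay on U2OS cells (Homo sapiens) for antiproliferative activity, read by MTT assay, with a stated time of 72 h (a lower number here means a stronger inhibitor, a higher number a weaker inhibitor), compound 1 gives > 100000 nM, which is a limit of the assay and not a number. Compound 2 also returns only a limit, > 100000 nM. Compound 3 likewise stops at a limit, > 100000 nM. Compound 1 therefore cannot be placed relative to either of the others; all three stand at the limit of > 100000 nM in this assay, at which 3 of the 3 values shown sit, and no ordering among them can be read. Going by the values given here, no step between two measured compounds exists.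

Compound 4 `O=C(CSc1cccc(O)c1)Nc1ccc2nc(NC(=O)c3ccc(C(F)(F)F)cc3)sc2c1` remains to be measured in this assay. It differs from compound 1 in one place: trifluoromethyl in place of hydrogen on an aromatic carbon. Among the compounds with values here, every value shown so far is a limit; no measured step supplies a size or direction for this change. For compound 4 the expected step is a step that the limit leaves unreadable from compound 1 to compound 4, within the scatter. Compound 4 is expected most likely to return another limit. Compound 4 is estimated at 150000 nM, with a range from 30000 nM to 1000000 nM.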

Compound 4, half-maximal inhibitory concentration: 630 nM
Compound 4: the middle estimate sits 240-fold (2.38 log units) above what was measured; the whole stated range lies above it.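

In this assay, trifluoromethyl in place of hydrogen on an aromatic carbon, para to a large group, gives an at least 150-fold lower number from compound 1 to compound 4 (2.20 log units; beyond the scatter). Compound 1 gives > 100000 nM, which is a limit of the assay and not a number, so the true size of this step cannot be read beyond what it prints. This single change from phenyl to 4-(trifluoromethyl)phenyl turns the series from one with no readable step into one with a measured value, showing that this position on the core of compound 1 can decide whether a number is obtained at all: the limit of > 100000 nM in this assay, at which 3 of the 4 values shown sit.

On these data alone, it remains open whether a chlorine, a methoxy or a nitrile on the same carbon would give a comparable step. Also open, as far as these compounds go, is whether trifluoromethyl elsewhere on this ring, or on the hydroxyphenyl ring, would do so.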